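Aryl tail variation on the piperidine of a TRPV1 antagonist series

The compounds below may be only part of what the source reports. "The series", "measured", "known", "first", "only" and "open" are said of these compounds alone.

Measured so far:
- compound 1 `Cc1ccc(CC2CCN(c3nc(C(F)(F)F)ccc3CNC(=O)C(C)c3ccc(NS(C)(=O)=O)c(F)c3)CC2)cc1`: 17 nM
- compound 2 `CC(C(=O)NCc1ccc(C(F)(F)F)nc1N1CCC(Cc2ccc(F)c(F)c2)CC1)c1ccc(NS(C)(=O)=O)c(F)c1`: 30 nM
- compound 3 `CC(C(=O)NCc1ccc(C(F)(F)F)nc1N1CCC(Cc2cc(F)cc(F)c2)CC1)c1ccc(NS(C)(=O)=O)c(F)c1`: 24 nM

All three share one core and differ only in the aryl group on the saturated chain carbon bound to the ring carbon. In a functional assay on CHO-K1 cells for antagonist activity at transient receptor potential cation channel subfamily V member 1 (Homo sapiens), read by FLIPR (on this read-out higher numbers stand for weaker inhibition and lower numbers for stronger inhibition), compound 3 gives 24 nM, the second highest of the three numbers; its nearest neighbour is compound 2 and its furthest is compound 1, and both gaps are within the scatter.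

Compound 4 `CC(C(=O)NCc1ccc(C(F)(F)F)nc1N1CCC(C(=O)c2ccc(F)cc2)CC1)c1ccc(NS(C)(=O)=O)c(F)c1` is the next step: (4-fluorophenyl)carbonyl in place of 3,5-difluorobenzyl on a saturated ring carbon. The measured steps that bear on it are a 1.8-fold higher number from compound 1 to compound 2 (0.25 log units; within the scatter), a 1.4-fold higher number from compound 1 to compound 3 (0.15 log units; within the scatter) and a 1.3-fold lower number from compound 2 to compound 3 (0.10 log units; within the scatter). Each of them swaps substituents on the aryl ring while keeping the benzyl link, and none moves beyond the scatter. For the measured compounds named here, the change to compound 4 goes further, since the saturated chain carbon is replaced by a carbonyl, and no measured pair covers such a change. The aryl substituent changes so far therefore suggest little movement, while the carbonyl adds an untested element, so a small step toward a higher number in this assay is expected, with a wide range.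

For compound 4 the expected value in this assay is 40 nM, between 12 nM and 130 nM, which means a step of a 1.7-fold higher number from compound 3 to compound 4 (0.22 log units; within the scatter).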

Compound 4, half-maximal inhibitory concentration: 990 nM
Compound 4: middle estimate off by 25-fold (1.39 log units), on the low side; the measured number lies above the stated range.
By their numbers in this assay, from the lowest: compounds 1, 3 and 2 (each within the scatter of the next); then compound 4.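

In this assay, the position that took aryl substituent swaps without a clear change while the benzyl link stayed in place does not take (4-fluorophenyl)carbonyl on the saturated ring carbon: the number rises against every benzyl compound (a 41-fold higher number from compound 3 to compound 4 (1.62 log units; beyond the scatter); a 33-fold higher number from compound 2 to compound 4 (1.52 log units; beyond the scatter); a 58-fold higher number from compound 1 to compound 4 (1.77 log units; beyond the scatter)), and all three steps are large and beyond the scatter. The flat picture from compounds 1, 2 and 3 therefore holds only among these benzyl groups and does not extend to this change, and none of the listed compounds goes against that reading. Nothing in the data at hand accounts for the size of these steps.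

A 4-fluorobenzyl group on the same ring carbon would separate the carbonyl from the fluorine pattern, since the two change together from each benzyl compound to compound 4. Also open, on these data alone, is how a hydroxyl-bearing carbon or an ether oxygen in the place of the carbonyl would read in this assay, and whether a carbonyl with a 3,5-difluorophenyl group would give a step of similar size.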